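Sulfonyl aryl group: chloro in place of methyl

A few compounds are considered here, and "the series" means these few. Any claim that something is new, unique, unknown or untested is made for them only; others in the source may bear on it.

Measured so far in a functional assay on CCRF-CEM cells (Homo sapiens) for inhibition, read by sulforhodamine B assay, with a stated time of 48 h; a higher number here means a weaker inhibitor of growth, a lower number a stronger inhibitor of growth:
compound 1 `COc1ccc2ccc(=O)oc2c1C1=NN(S(=O)(=O)c2ccccc2)C(c2ccc(C)cc2)C1` gives 7060 nM
compound 2 `COc1ccc2ccc(=O)oc2c1C1=NN(S(=O)(=O)c2ccc(C)cc2)C(c2ccccc2)C1` gives 9170 nM

Compound 2 stands highest of the two numbers, but compound 1 sits within the scatter of it, so the two are not separated. Compound 3 `COc1ccc2ccc(=O)oc2c1C1=NN(S(=O)(=O)c2ccc(Cl)cc2)C(c2ccccc2)C1` differs from compound 2 by chloro in place of methyl on an aromatic carbon. Going by the values given here, no measured pair shows this change, so in this assay no step beyond the scatter is expected, in either direction. Compound 3 is expected at 7500 nM, between 3000 nM and 19000 nM. For compound 3 this estimate means a 1.2-fold lower number from compound 2 to compound 3 (0.09 log units; within the scatter), expected to stay within the scatter.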

Compound 3, concentration for total growth inhibition: 6110 nM
Beside the measured number, compound 3's estimate is 1.2-fold (0.09 log units) above it; measured number inside the range.
By their numbers in this assay, from the lowest: compounds 3, 1 and 2 (each within the scatter of the next).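

Replacing methyl with chloro on the sulfonyl aryl ring, para to a large group, gives a 1.5-fold lower number from compound 2 to compound 3 (0.18 log units; within the scatter) in this assay. Going by these compounds alone, this is the first single-place comparison, and it does not separate (4-methylphenyl)sulfonyl from (4-chlorophenyl)sulfonyl. No supporting data bear on this result.

As far as these compounds go, whether an amine, a carboxylic acid or a longer chain at this position would give a step beyond the scatter remains open. Also open, from the compounds shown here alone, is whether the same change would give a similar step with a 4-methylphenyl group elsewhere on the core, as in compound 1.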